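An Amino Group in Place of Trifluoromethyl

The compounds below may be only part of what the source reports. "The series", "measured", "known", "first", "only" and "open" are said of these compounds alone.

Two measured compounds share one core and differ only in the ring attached to it. Compound 1 `COC(=O)c1sc2cc(-c3cccs3)cnc2c1N` was tested in a functional assay on A-375 cells (Homo sapiens) for inhibition, read by sulforhodamine B assay, with a stated time of 48 h; a lower number here means a stronger inhibitor of growth, a higher number a weaker inhibitor of growth. In this assay compound 1 gives > 150000 nM, which is a limit of the assay rather than a number. Compound 2 `COC(=O)c1sc2cc(-c3ccc(C(F)(F)F)cc3)cnc2c1N` carries a trifluoromethyl group on its six-membered aromatic ring of carbon only. In this assay compound 2 gives > 150000 nM, again a limit and not a number. Both results sit at the same point, (the limit of > 150000 nM in this assay, at which 2 of the 2 values shown sit), so compound 2 stands exactly where compound 1 stands. Compound 3 `COC(=O)c1sc2cc(-c3ccc(N)cc3)cnc2c1N` arises from compound 2 by the change (amino in place of trifluoromethyl on an aromatic carbon). Among the measured compounds shown here, no measured step between compounds is available to guide the expectation, so the change is expected to bring no shift beyond the scatter, and the step is estimated as a number no higher from compound 2 to compound 3 (the limit leaves the size open). Compound 3 is therefore expected to give about 150000 nM, between 50000 nM and 300000 nM.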

Compound 3, concentration for 50% growth inhibition: 80800 nM
Compound 3: the middle estimate sits 1.9-fold (0.27 log units) above what was measured; measured number inside the range.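

Among the compounds shown here, compound 3 is the first compound here to give a number rather than a limit in this assay, so a change at this place on the six-membered aromatic ring can bring growth inhibition into measurable range. Amino in place of trifluoromethyl gives an at least 1.8-fold lower number from compound 2 to compound 3 (0.26 log units; that floor lies within the scatter), and 4-aminophenyl in place of thiophen-2-yl gives an at least 1.8-fold lower number from compound 1 to compound 3 (0.26 log units; that floor lies within the scatter). Both steps are only floors, and their true sizes stay open, since each starts from a limit: the limit of > 150000 nM in this assay, at which 2 of the 3 values shown sit.

The compounds shown leave open whether the amino group itself matters or whether losing trifluoromethyl is enough. A hydroxyl group, a methylamino group or a carboxylic acid at the same place, or a plain hydrogen there, would help separate these two readings.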